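Methyl to Fluoro on the Sulfonyl Ring of Compound 2

The source may report more compounds than this note shows. Statements on the series, on what has been measured and on what is new or still open speak of the compounds shown alone.

Compound 2 `COc1ccccc1C(=O)NCc1ccc(CNS(=O)(=O)c2cccc(C)c2)cc1` gives 1000 nM in an assay on MDA-MB-231 cells for displacement of a labelled ligand from C-X-C chemokine receptor type 4 (Homo sapiens), read by fluorescence and microscopy, with stated times of 10 min and 30 min (a higher number here means that more compound is needed for the effect, a lower number that less compound is needed), and stands highest of the three measured compounds. Compound 1 `Cc1cccc(S(=O)(=O)NCc2ccc(CNC(=O)c3cccnc3)cc2)c1` gives 10 nM in this assay, and compound 3 `Cc1ccccc1C(=O)NCc1ccc(CNS(=O)(=O)c2ccc(F)cc2)cc1` gives 10 nM, both lower than compound 2 by amounts beyond the scatter. For the measured compounds named here, the only single-point step measured is a 100-fold higher number from compound 1 to compound 2 (2.00 log units; beyond the scatter), and it concerns the group on the carbonyl carbon, not the sulfonyl ring.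

Compound 4 `COc1ccccc1C(=O)NCc1ccc(CNS(=O)(=O)c2cccc(F)c2)cc1` differs from compound 2 in fluoro in place of methyl on an aromatic carbon. Going by the values given here, no measured step touches this change. Among the compounds with values here, compound 3 also carries a fluoro on its sulfonyl ring, but it differs from compound 2 in two places at once, so its value shows only that a fluoro-bearing compound of this series can give a low number, not what the fluoro alone contributes. The expectation is therefore a step of no size beyond the scatter, no change at the digits printed from compound 2 to compound 4 (within the scatter). Compound 4 is estimated at 1000 nM in this assay, within a range from 300 nM to 3000 nM.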

Compound 4, effective concentration (reported as EC, without a stated level of effect): 1000 nM
Estimate against measurement, compound 4: no gap at the digits printed; low and high end bracket the measured number.
By their numbers in this assay, from the lowest: compounds 1 and 3 (each within the scatter of the next); then compounds 2 and 4 (each within the scatter of the next).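

In this assay, for the compounds shown here, fluoro in place of methyl on an aromatic carbon of the sulfonyl ring, meta to a large group, gives no change at the digits printed from compound 2 to compound 4 (within the scatter), the first single-point reading at this position. With the 2-methoxyphenyl group on the carbonyl carbon held fixed, the 3-methylphenyl and 3-fluorophenyl forms of the sulfonyl group cannot be told apart, so this one exchange does not recover the low number seen for compound 1. Nothing given here explains why these two groups read alike.

As far as these compounds go, it remains open whether the same exchange would also leave the number unchanged with pyridin-3-yl on the carbonyl carbon. Also open, from the compounds shown here alone, is whether an amine, a carboxylic acid or a longer chain at this position would shift the number beyond the scatter.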